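Swapping the side chain on a B-cell-active core

The source may hold more compounds than are shown below. What is called first, only, known or untested is meant among the compounds shown, and "the series" means these compounds.

Of the compounds shown here, three have been measured in a functional assay on the whole organism (B cells) with Mus musculus as the target; a higher number here means a larger maximal response, a lower number a smaller maximal response. Compound 1 `C=CCn1c(=O)n(CCCCO)c2nc(N)nc(O)c21` gives 12%. Compound 2 `NCC(O)Cn1c(=O)n(C2OC(CO)[C@@H](O)[C@H]2O)c2nc(N)nc(O)c21` gives 110%, and compound 3 `C=CCSc1nc2c(O)nc(N)nc2n1C1OC(CO)[C@@H](O)[C@H]1O` gives 107%. Among these, compound 2 carries the largest number, but compound 3 lies within the usual scatter of it, so the two cannot be told apart; compound 1 sits well below both.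

Compound 4 `Nc1nc(O)c2c(n1)n(C1OC(CO)[C@@H](O)[C@H]1O)c(=O)n2CCN1CCCCC1` has not yet been measured. It is compound 2 with one change: (piperidin-1-yl)methyl in place of 2-amino-1-hydroxyethyl on a saturated chain carbon bound to an aromatic nitrogen. The rest of the molecule is kept. For the measured compounds named here, no measured pair shows this exact change, so its effect can only be guessed from the spread of the three numbers. Because compound 3 gives 107% while differing from compound 2 elsewhere in the molecule, the shared part appears to carry most of the response, and the chain swap is expected to bring only a modest step downward, if any, meaning a change of a number 15 percentage points lower from compound 2 to compound 4 (beyond the scatter). Compound 4 is therefore expected to give about 95%, with a likely range from 60% to 115%.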

Compound 4, largest response reached (reported as maximal response), in percent of the reference or control that the assay uses: 0%
Beside the measured number, compound 4's estimate is 95 percentage points above it; the whole stated range lies above it.
By their numbers in this assay, from the lowest: compound 4; then compound 1; then compounds 3 and 2 (each within the scatter of the next).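

In this assay, putting (piperidin-1-yl)methyl in place of 2-amino-1-hydroxyethyl on a saturated chain carbon bound to an aromatic nitrogen gives a number 110 percentage points lower from compound 2 to compound 4 (beyond the scatter), so the shared rest of the molecule does not secure the response on its own and this side chain matters greatly. The change alters several things at once: the hydroxyl and the primary amine leave, and a six-membered non-aromatic ring enters, so this single step cannot show which of these counts. No measurement here explains the loss of response.

Still open, from the compounds shown here alone, is whether an open-chain 2-(dimethylamino)ethyl or a 3-aminopropyl chain without the hydroxyl would keep the response. Also open, going by these compounds, is how a carboxylic acid or a longer chain would behave at this position.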